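This account rests on a few compounds, and the source may have more. Where it says the series, first, only, none or still open, it means among the compounds named here.

Among the measured compounds shown here, in a functional assay on MDA-MB-436 cells (Homo sapiens) for antiproliferative activity, read by MTT assay, with a stated time of 48 h (a lower number here means a stronger inhibitor, a higher number a weaker inhibitor), compound 2 `CN1CCN(c2ccc(-c3cc4c(N5CCN(S(=O)(=O)C6CC6)CC5)ncnc4s3)cc2)CC1` gives 10600 nM, the only measured number among the compounds here. Compound 1 `C=CS(=O)(=O)N1CCN(c2nc(OC[C@H]3CCCN3C)nc3sccc23)CC1` gives only a limit of the assay, > 50000 nM, which is the limit of > 50000 nM in this assay, at which 1 of the 2 values shown sits. Compound 3 `COc1ccccc1NC(=O)N1CCN(c2ncnc3sc(-c4ccc(N5CCN(C)CC5)cc4)cc23)CC1` differs from compound 2 in a single place: (2-methoxyphenyl)carbamoyl in place of cyclopropylsulfonyl on an amine nitrogen in a ring. For the measured compounds named here, no measured pair of compounds shows a change of this kind, so the expected step is a small one, within the usual scatter or at most a modest gain, namely a 1.3-fold lower number from compound 2 to compound 3 (0.12 log units; within the scatter). Compound 3 is therefore estimated at 8000 nM, with a likely range from 2000 nM to 40000 nM.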

Compound 3, half-maximal inhibitory concentration: 26300 nM
Compound 3: the middle estimate sits 3.3-fold (0.52 log units) below what was measured; low and high end bracket the measured number.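

Swapping cyclopropylsulfonyl for the larger (2-methoxyphenyl)carbamoyl on this amine nitrogen in a ring brings a 2.5-fold higher number from compound 2 to compound 3 (0.39 log units; beyond the scatter) in this assay, so here the bigger group weakens the compound modestly rather than helping. Among the compounds shown here, this is the only readable step at this position, and compound 3 still gives a true number. Compound 1 differs in more than one place and gives only a limit: the limit of > 50000 nM in this assay, at which 1 of the 3 values shown sits.

As far as these compounds go, whether a small acetyl or a plain methyl on this nitrogen would do better stays open. So does the part played by the methoxy, which an unsubstituted phenylcarbamoyl would test.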